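A few compounds are considered here, and "the series" means these few. Any claim that something is new, unique, unknown or untested is made for them only; others in the source may bear on it.

In an ADME assay on HOS cells (Homo sapiens) for cytotoxicity (a higher number here means that more compound is tolerated, a lower number that less compound is tolerated), compound 1, `CN(Cc1nc2cccc(C(=O)NCCCCN)c2[nH]1)C1CCCc2cccnc21`, gives > 20000 nM, which is a limit of the assay and not a number. For the measured compounds named here, compound 2, `CN(Cc1nc2cccc(CCCN3CCCC3)c2[nH]1)C1CCCc2cccnc21`, gives 8200 nM, the only actual number so far. Compound 3, `CN(Cc1nc2cccc(N3CCNCC3)c2[nH]1)C1CCCc2cccnc21`, is the next to be read: piperazin-1-yl in place of 3-(pyrrolidin-1-yl)propyl on an aromatic carbon. In words, piperazin-1-yl stands in place of 3-(pyrrolidin-1-yl)propyl on an aromatic carbon of a six-membered aromatic ring of carbon only.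

Going by the values given here, one measured step bears on this change, as it also swaps the group on an aromatic carbon: an at least 2.4-fold lower number from compound 1 to compound 2 (0.38 log units; beyond the scatter). That step is open-ended in size, given (the limit of > 20000 nM in this assay, at which 1 of the 2 values shown sits). It is also a single step, so it offers only weak guidance. Compound 3 gives up the 3-(pyrrolidin-1-yl)propyl group that compound 2 carries at 8200 nM, so a modest move back towards more compound tolerated is expected in this assay. The expected step is a 1.6-fold higher number from compound 2 to compound 3 (0.20 log units; within the scatter). For compound 3 the estimated value is 13000 nM, with an expected range of 6000 nM to 28000 nM.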

Compound 3, half-maximal cytotoxic concentration: > 20000 nM
Compound 3: only a limit was reported; the forecaster's own chance of this, stated with the estimate: 35%; at least 1.5-fold (0.18 log units) between middle value and limit.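

On an aromatic carbon of the six-membered aromatic ring of carbon only, piperazin-1-yl in place of 3-(pyrrolidin-1-yl)propyl gives, in this assay, an at least 2.4-fold higher number from compound 2 to compound 3 (0.38 log units; beyond the scatter). Together with an at least 2.4-fold lower number from compound 1 to compound 2 (0.38 log units; beyond the scatter), this leaves compound 2 as the only one of the three compounds with an actual number, so among the compounds shown the lower number goes with the 3-(pyrrolidin-1-yl)propyl group and not with the shared core alone. The step between compound 1 and compound 3 cannot be read, so neither (4-aminobutyl)carbamoyl nor piperazin-1-yl can be ranked over the other, and both steps to compound 2 stay open-ended in size: the limit of > 20000 nM in this assay, at which 2 of the 3 values shown sit.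

The compounds shown do not separate the propyl chain from the ring at its end, which 3-(piperazin-1-yl)propyl or pyrrolidin-1-yl set directly on the same aromatic carbon would do. A carboxylic acid at this place would show whether the number stays at the limit when the group carries no amine.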